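Hydrazone series: 4-hydroxyphenyl to 2,4-dichlorophenyl

This account rests on a few compounds, and the source may have more. Where it says the series, first, only, none or still open, it means among the compounds named here.

Within the data shown here, in a functional assay on MDA-MB-435 cells (Homo sapiens) for inhibition, read by sulforhodamine B assay, with a stated time of 48 h (a higher number here means a weaker inhibitor of growth, a lower number a stronger inhibitor of growth), compound 1 (`O=C(Cc1csc2nc(-c3ccc(Br)cc3)cn12)N/N=C/c1ccccc1`) gives 51300 nM and compound 2 (`O=C(Cc1csc2nc(-c3ccc(Br)cc3)cn12)N/N=C/c1ccc(O)cc1`) gives 24500 nM as the lower of the two numbers so far. Compound 3 (`O=C(Cc1csc2nc(-c3ccc(Br)cc3)cn12)N/N=C/c1ccc(Cl)cc1Cl`) is the next to read, and it differs from compound 2 as follows: 2,4-dichlorophenyl in place of 4-hydroxyphenyl on a carbon with a double bond to nitrogen with 2,4-dichlorophenyl in place of 4-hydroxyphenyl on a carbon with a double bond to nitrogen. Among the measured compounds shown here, one measured step bears on this, a 2.1-fold lower number from compound 1 to compound 2 (0.32 log units; beyond the scatter) for hydroxy in place of hydrogen on an aromatic carbon, which is modest but beyond the scatter. For the measured compounds named here, compound 3 has no hydroxy, like compound 1, but no measured compound shows what chlorine does here. In this assay the expected step is a 1.2-fold higher number from compound 2 to compound 3 (0.09 log units; within the scatter) and so none beyond the scatter. For compound 3 the estimate is 30000 nM with an expected range of 10000 nM to 80000 nM on this reading.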

Compound 3, concentration for total growth inhibition: > 100000 nM
Compound 3 was reported as a limit; the forecaster's own chance of this, stated with the estimate: 10%; at least 3.3-fold (0.52 log units) between middle value and limit.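

Compound 3 gives no number in this assay, only a limit: the limit of > 100000 nM in this assay, at which 1 of the 3 values shown sits.

Even so, the group on the carbon with a double bond to nitrogen clearly matters in this series: 2,4-dichlorophenyl in place of 4-hydroxyphenyl gives an at least 4.0-fold higher number from compound 2 to compound 3 (0.61 log units; beyond the scatter), a step in the direction of weaker growth inhibition that is larger than the gain seen on adding hydroxy. Against the plain phenyl of compound 1, the same group gives an at least 1.9-fold higher number from compound 1 to compound 3 (0.28 log units; that floor lies within the scatter), so the floor of this step does not yet separate compound 3 from compound 1, and no loss can be assigned to the chlorines themselves.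

Going by these compounds, how far compound 3 lies past its limit stays open, as does whether one chlorine would act like the two in 2,4-dichlorophenyl. On these data alone, what a methoxy group or an amine would give in place of the hydroxy of compound 2 is also open.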